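The compounds below may be only part of what the source reports. "The series", "measured", "known", "first", "only" and "open" are said of these compounds alone.

Measured in a functional assay on DU-145 cells (Homo sapiens) for inhibition, read by trypan blue exclusion, with a stated time of 96 h; a lower number here means a stronger inhibitor of growth, a higher number a weaker inhibitor of growth:
- compound 1 `COc1ccccc1/C=C(/SCc1ccc(Cl)c(Cl)c1)C(=O)c1ccc(Cl)cc1`: 10000 nM
- compound 2 `O=C(/C(=C\c1c(O)cc(O)cc1O)SCc1ccc(Cl)c(Cl)c1)c1ccc(Cl)cc1`: 25000 nM
- compound 3 `CN(C)c1ccc(/C=C(/SCc2ccc(Cl)c(Cl)c2)C(=O)c2ccc(Cl)cc2)cc1`: 50000 nM

Compound 3 and compound 2 sit level, as a 2.0-fold higher number from compound 2 to compound 3 (0.30 log units; within the scatter) lies within the scatter. Compound 1 gives the lower number, and a 5.0-fold higher number from compound 1 to compound 3 (0.70 log units; beyond the scatter) is a modest step beyond the scatter.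

Compound 4 `O=C(/C(=C\c1ccc(O)cc1)SCc1ccc(Cl)c(Cl)c1)c1ccc(Cl)cc1` differs from compound 3 at a single place: hydroxy in place of dimethylamino on an aromatic carbon. This puts hydroxy in place of dimethylamino on an aromatic carbon, para to a large group. Among the compounds with values here, no measured pair makes exactly this swap, so the evidence is indirect. The closest guide is compound 2, which also carries hydroxy groups and gives 25000 nM. The group at this part of the molecule has so far moved the number only modestly, as a 5.0-fold higher number from compound 1 to compound 3 (0.70 log units; beyond the scatter) shows, so a large change would be a surprise. A modest move toward a lower number is expected, namely a 2.5-fold lower number from compound 3 to compound 4 (0.40 log units; beyond the scatter). Compound 4 is estimated at 20000 nM, with an expected range from 7000 nM to 50000 nM.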

Compound 4, concentration for 50% growth inhibition: 1000 nM
The estimate for compound 4 lay 20-fold (1.30 log units) above the measured number; measured number outside the range, below it.
By their numbers in this assay, from the lowest: compound 4; then compound 1; then compounds 2 and 3 (each within the scatter of the next).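

Until now, changing the aromatic group on this double-bonded chain carbon had moved the number only modestly, but this result shows that the position can matter far more: putting hydroxy in place of dimethylamino brings a 50-fold lower number from compound 3 to compound 4 (1.70 log units; beyond the scatter). Adding more hydroxy groups does not repeat the effect, as 4-hydroxyphenyl in place of 2,4,6-trihydroxyphenyl brings a 25-fold lower number from compound 2 to compound 4 (1.40 log units; beyond the scatter). The single hydroxy also outdoes the 2-methoxyphenyl group, with a 10-fold lower number from compound 1 to compound 4 (1.00 log units; beyond the scatter), and nothing measured here explains why this compound stands apart.

The compounds shown leave open whether the hydroxy itself is required on this aromatic carbon, para to a large group, and a methoxy or a primary amine at that same place would test this. They also leave open whether a carboxylic acid there would keep the low number.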